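This account rests on a few compounds, and the source may have more. Where it says the series, first, only, none or still open, it means among the compounds named here.

Compound 1 `CCCOC(=O)C1=C(C)NC(=S)NC1c1ccoc1`: 45%
Compound 2 `CC1=C(C(=O)OCC(C)C)C(c2ccoc2)NC(=S)N1`: 1%
Compound 3 `CC1=C(C(=O)OCc2ccccc2)C(c2ccoc2)NC(=S)N1`: 36%

Of the compounds shown here, three have been measured in an assay on membranes from HEK293 cells for displacement of a labelled ligand from adenosine receptor A2b (Homo sapiens), read by scintillation counting, with a stated time of 30 min, tested at 1 uM; a lower number here means less inhibition, a higher number more inhibition at the concentration tested (going by the name of the read-out). Compound 2 stands lowest of the three numbers: a number 44 percentage points lower from compound 1 to compound 2 (beyond the scatter), and a number 35 percentage points higher from compound 2 to compound 3 (beyond the scatter), both beyond the scatter. Between compound 1 and compound 3 the change is smaller, a number 9 percentage points lower from compound 1 to compound 3 (within the scatter), within the scatter.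

Compound 4 `CC1=C(C(=O)OCC(C)C)C(c2ccsc2)NC(=S)N1` differs from compound 2 in one place: thiophen-3-yl in place of furan-3-yl on a saturated ring carbon. All three measured steps concern the group on the saturated chain carbon bound to an oxygen next to a carbonyl group, and none of them changes the group on the saturated ring carbon. Among the compounds with values here, no measured step therefore bears directly on the change from furan-3-yl to thiophen-3-yl, and the data give no basis for a large move in either direction. Because compound 2 gives 1%, the number can hardly fall further, so any change is expected to be a small rise or none beyond the scatter. For compound 4 the expected value in this assay is 10%, with a range from 0% to 35%. This estimate means a step of a number 9 percentage points higher from compound 2 to compound 4 (within the scatter).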

Compound 4, a percentage reported as inhibition, at one concentration (the size of the read-out at that concentration, not a potency): 15%
Compound 4: middle estimate off by 5 percentage points, on the low side, and the stated range covers the measured number.
By their numbers in this assay, from the lowest: compound 2; then compound 4; then compounds 3 and 1 (each within the scatter of the next).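

Within the data shown here, every earlier step in this assay changed a chain group elsewhere on the molecule, so this pair gives the first reading at the saturated ring carbon of the six-membered non-aromatic ring, where thiophen-3-yl in place of furan-3-yl gives a number 14 percentage points higher from compound 2 to compound 4 (beyond the scatter). The result shows that this position responds even to a close exchange: both groups are five-membered aromatic rings with the same counts of heavy atoms, donors and acceptors, differing in the counted atoms only by sulfur in place of oxygen, and the number still moves beyond the scatter, though the step is modest. No available evidence bears on what lies behind this step.

Going by these compounds, the step is known only with the chain of compound 2, so whether thiophen-3-yl gives a similar change with the chains of compound 1 or compound 3 remains open. On these data alone, what other groups would give at this saturated ring carbon, such as thiophen-2-yl, furan-2-yl or pyridin-3-yl, also remains open.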